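The source may hold more compounds than are shown below. What is called first, only, known or untested is meant among the compounds shown, and "the series" means these compounds.

In a functional assay on PC-3 cells (Homo sapiens) for cytotoxicity, read by MTT assay, with a stated time of 96 h (a higher number here means a weaker inhibitor, a lower number a stronger inhibitor), three compounds on a shared core have been measured. Compound 1 `CC[C@H](N)C(=O)N[C@@H]1C(=O)N2[C@@H](CC[C@@H]1CCN)CC[C@H]2C(=O)NC(c1ccccc1)c1ccccc1`, with an amino group on a saturated chain carbon, gives 85200 nM. Compound 2 `CC[C@H](N)C(=O)N[C@@H]1C(=O)N2[C@@H](CC[C@@H]1CCO)CC[C@H]2C(=O)NC(c1ccccc1)c1ccccc1`, with hydroxy in place of that amino group, reads > 100000 nM, which is a limit and not a number. Compound 3 `CC[C@H](N)C(=O)N[C@@H]1C(=O)N2[C@@H](CC[C@@H]1CCNC(=O)NCc1ccccc1)CC[C@H]2C(=O)NC(c1ccccc1)c1ccccc1`, with benzylcarbamoyl on the amine nitrogen, reads > 100000 nM, again a limit. That leaves the series mostly at one mark: the limit of > 100000 nM in this assay, at which 2 of the 3 values shown sit.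

Compound 4 `CC[C@H](N)C(=O)N[C@@H]1C(=O)N2[C@@H](CC[C@@H]1CCNCc1ccccc1)CC[C@H]2C(=O)NC(c1ccccc1)c1ccccc1` differs from compound 3 by benzyl in place of benzylcarbamoyl on an amine nitrogen.

Among the measured compounds shown here, two measured steps bear on this change. The closer one adds benzylcarbamoyl to the amine nitrogen of compound 1 and is an at least 1.1-fold higher number from compound 1 to compound 3 (0.06 log units; that floor lies within the scatter). The other exchanges amino for hydroxy and is an at least 1.1-fold higher number from compound 1 to compound 2 (0.06 log units; that floor lies within the scatter). For the measured compounds named here, neither shows a change beyond the scatter, and no measured compound carries benzyl on this nitrogen.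

Compound 4 shares with compound 1, at 85200 nM, an amine nitrogen without the carbamoyl, so a number near that value is expected, with only a modest move toward lower numbers. The expected step is an at least 1.4-fold lower number from compound 3 to compound 4 (0.15 log units; that floor lies within the scatter). For compound 4 the estimated value is 70000 nM, with an expected range from 25000 nM to 150000 nM.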

Compound 4, half-maximal inhibitory concentration: 39200 nM
Compound 4: middle estimate off by 1.8-fold (0.25 log units), on the high side; measured number inside the range.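

In this assay, among the compounds shown here, this is the first change at the amine nitrogen that reads beyond the scatter: benzyl in place of hydrogen gives a 2.2-fold lower number from compound 1 to compound 4 (0.34 log units; beyond the scatter), a modest step. The carbonyl-bearing link matters as well, since compound 3 and compound 4 both carry an aromatic ring on this nitrogen, yet benzyl in place of benzylcarbamoyl gives an at least 2.5-fold lower number from compound 3 to compound 4 (0.40 log units; beyond the scatter), and benzylamino in place of hydroxy gives an at least 2.5-fold lower number from compound 2 to compound 4 (0.40 log units; beyond the scatter). Compound 4 therefore stands clear of the mark shared by compound 2 and compound 3, which is a limit of the assay and not a number: the limit of > 100000 nM in this assay, at which 2 of the 4 values shown sit.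

The compounds shown do not tell whether the lower number comes from the aromatic ring itself or from any carbon group on this nitrogen, a question that a methyl or a cyclohexylmethyl group there would help to separate. They also leave open how the number responds to a longer chain leading to the ring, as in phenethyl, or to a chlorine or a methoxy group on the ring.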